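The source may hold more compounds than are shown below. What is called first, only, known or untested is meant among the compounds shown, and "the series" means these compounds.

Going by the values given here, compound 3 `Cc1ccc(C)c(Nc2c(-c3ccc4[nH]nc(C)c4c3)nc3cnc(N4CCN(C)CC4)cn23)c1` is one of three compounds measured in a functional assay on MV4-11 cells (Homo sapiens) for inhibition, with a stated time of 120 h, tested at 10 uM; on this read-out higher numbers stand for more inhibition at the one concentration tested (going by the name of the read-out) and lower numbers for less inhibition. In this assay compound 3 gives 0%. Compound 1 `Cc1n[nH]c2ccc(-c3nc4cnc(N5CCN(C)CC5)cn4c3Nc3ccccc3F)cc12` gives 0% in this assay, and compound 2 `Cc1n[nH]c2ccc(-c3nc4cnc(N5CCN(C)CC5)cn4c3Nc3ccccc3)cc12` gives 0%. Compound 3 therefore stands level with both of them: no change at the digits printed from compound 1 to compound 3 (within the scatter), and no change at the digits printed from compound 2 to compound 3 (within the scatter). The smaller exchange on the same ring, no change at the digits printed from compound 1 to compound 2 (within the scatter), likewise leaves the read-out where it was.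

Compound 4 `Cc1n[nH]c2ccc(-c3nc4cnc(N5CCN(C)CC5)cn4c3Nc3ccc(Cl)cc3F)cc12` differs from compound 3 in one place: 4-chloro-2-fluorophenyl in place of 2,5-dimethylphenyl on a nitrogen on an aromatic ring. The measured steps that bear on this are the two exchanges of the aryl group on that nitrogen ending at compound 3, and both were flat; a fluoro, a plain phenyl and a 2,5-dimethylphenyl all gave the same read-out. Nothing in the set points to a move beyond the scatter, so no step is expected in this assay; the expected step is no change at the digits printed from compound 3 to compound 4 (within the scatter). Compound 4 is accordingly estimated at 0%, with a range from 0% to 15%.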

Compound 4, a percentage reported as inhibition, at one concentration (the size of the read-out at that concentration, not a potency): 0%
Beside the measured number, compound 4's estimate shows no gap at the digits printed, within the range that was stated.
By their numbers in this assay, from the lowest: compounds 1, 2, 3 and 4 (each within the scatter of the next).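

The new compound extends the flat picture to halogen substitution on the aryl group carried on a nitrogen on an aromatic ring. In this assay, 4-chloro-2-fluorophenyl in place of 2,5-dimethylphenyl gives no change at the digits printed from compound 3 to compound 4 (within the scatter), and the same group in place of phenyl gives no change at the digits printed from compound 2 to compound 4 (within the scatter). The step of a new kind, chloro in place of hydrogen on an aromatic carbon of the 2-fluorophenyl group, gives no change at the digits printed from compound 1 to compound 4 (within the scatter). No measured evidence bears on this result.

The compounds shown leave open whether any group on this aryl ring, such as an amine or a carboxylic acid, can move the read-out away from this shared level. They also leave open whether a change elsewhere on the shared core would do so.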